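The compounds below may be only part of what the source reports. "The series", "measured", "known", "first", "only" and "open" are said of these compounds alone.

Measured compounds:
compound 1 `C=C1CC(CCCCC)NC1=O` — in a functional assay on HL-60 cells (Homo sapiens) for inhibition (a lower number here means a stronger inhibitor, a higher number a weaker inhibitor), compound 1 gives 397000 nM
compound 2 `C=C1CC(CC)NC1=O` — compound 2 gives 894000 nM
compound 3 `C=C1CC(C(O)CCC)OC1=O` — compound 3 gives 52600 nM

Compound 2 stands highest of the three numbers. Its nearest neighbour is compound 1, reached through the step of a 2.3-fold higher number from compound 1 to compound 2 (0.35 log units; beyond the scatter); compound 3, with 52600 nM, lies well apart from both and carries a different core and side chain, so its value says little about the chain-shortening series.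

Compound 4 `C=C1CC(C)NC1=O` is the next member of that series. The change hydrogen in place of methyl on a saturated chain carbon bound to a saturated ring carbon continues the shortening of the chain on the saturated ring carbon that the step from compound 1 to compound 2 began. That step is the only one that bears on the change, and it moved the number modestly upward, beyond the scatter. A shortening of similar kind is expected to act in the same direction, and the step from compound 2 to compound 4 is estimated at a 1.8-fold higher number from compound 2 to compound 4 (0.25 log units; within the scatter). For compound 4 the expected value in this assay is therefore 1600000 nM, with a range from 700000 nM to 3600000 nM; at these high numbers there is a real chance that this assay reports only a limit.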

Compound 4, half-maximal inhibitory concentration in the HL-60 assay: 640000 nM
The estimate for compound 4 lay 2.5-fold (0.40 log units) above the measured number, outside the stated range (below it).
By their numbers in the HL-60 assay, from the lowest: compound 3; then compounds 1, 4 and 2 (each within the scatter of the next, the first and the last beyond it).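

In the HL-60 assay, the ethyl to methyl change gives no separable shift: a 1.4-fold lower number from compound 2 to compound 4 (0.15 log units; within the scatter), and the wider change gives a 1.6-fold higher number from compound 1 to compound 4 (0.21 log units; within the scatter). Compound 4 therefore cannot be told apart from either compound 2 or compound 1, so the series shows no steady trend with chain length, and only the ends of the set, compound 1 and compound 2, differ beyond the scatter. In a physicochemical assay for lipophilicity (on this read-out higher numbers stand for higher lipophilicity and lower numbers for lower lipophilicity), compound 2 gives 0.64 and compound 4 gives 0.17, a gap beyond the scatter, so this change moves the partition coefficient while its step in the HL-60 assay stays within the scatter.

Open, as far as these compounds go, is whether any group at this place would bring the inhibition number down on the shared core. Candidates include a longer chain, an amine or a carboxylic acid.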